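Swapping an Acyl Group for Methylsulfonyl on the Shared Core

This account rests on a few compounds, and the source may have more. Where it says the series, first, only, none or still open, it means among the compounds named here.

Measured compounds:
- compound 1 `CN(C)c1ccc(C2CC(c3ccc(-n4cncn4)cc3)=NN2C(=O)CCCl)cc1`: -3.4%
- compound 2 `CN(C)c1ccc(C2CC(c3ccc(-n4cncn4)cc3)=NN2C(=O)c2cc(Cl)cc(Cl)c2)cc1`: 5.3%
- compound 3 `CN(C)c1ccc(C2CC(c3ccc(-n4cncn4)cc3)=NN2C(=O)/C=C/c2ccccc2)cc1`: -3.7%

In a functional assay on HCC1806 cells (Homo sapiens) for inhibition, read by sulforhodamine B assay, tested at 10 uM (on this read-out lower numbers stand for less inhibition and higher numbers for more inhibition at the one concentration tested (going by the name of the read-out)), compound 3 gives -3.7%, the lowest of the three numbers, but its distance to compound 1 and to compound 2 lies within the scatter, so the three are not distinguishable. Compound 4 `CN(C)c1ccc(C2CC(c3ccc(-n4cncn4)cc3)=NN2S(C)(=O)=O)cc1` differs from compound 3 in one place: methylsulfonyl in place of (2-phenylethenyl)carbonyl on an amine nitrogen in a ring.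

The measured steps all swap one group on the shared core: a number 8.7 percentage points higher from compound 1 to compound 2 (within the scatter), a number 0.3 percentage points lower from compound 1 to compound 3 (within the scatter), a number 9 percentage points lower from compound 2 to compound 3 (within the scatter). None moved the read-out beyond the scatter. For the measured compounds named here, no measured step replaces an acyl group with a sulfonyl group, so the change to compound 4 has no direct precedent; what the three compounds show is that varying the group on the amine nitrogen in the ring has so far left inhibition near zero. The expectation for compound 4 is therefore a step of a number 3.7 percentage points higher from compound 3 to compound 4 (within the scatter), not beyond the scatter.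

Compound 4 is estimated to give 0%, between -12% and 12%.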

Compound 4, a percentage reported as inhibition, at one concentration (the size of the read-out at that concentration, not a potency): 10.8%
For compound 4 the middle estimate is 10.8 percentage points below the measured one; measured number inside the range.
By their numbers in this assay, from the lowest: compounds 3, 1, 2 and 4 (each within the scatter of the next, the first and the last beyond it).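

In this assay, for the compounds shown here, methylsulfonyl on the amine nitrogen in the ring gives the only steps at this position that pass the scatter, though both are modest: (a number 14.5 percentage points higher from compound 3 to compound 4 (beyond the scatter)) and (a number 14.2 percentage points higher from compound 1 to compound 4 (beyond the scatter)). Compound 2 goes against a simple sulfonyl-over-acyl pattern, since (a number 5.5 percentage points higher from compound 2 to compound 4 (within the scatter)) leaves compound 4 indistinguishable from the compound carrying (3,5-dichlorophenyl)carbonyl. The position therefore can move the read-out a little, but nothing shown explains why.

Methylsulfonyl differs from the acyl groups in both its sulfonyl link and its size, so these compounds cannot separate the two. An acetyl group, which is a small acyl, or a phenylsulfonyl group, which is a larger sulfonyl, would pull those two differences apart on the shared core.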